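Methoxy for Methyl Where Every Value Is a Limit

This account rests on a few compounds, and the source may have more. Where it says the series, first, only, none or still open, it means among the compounds named here.

Compound 1 `Cc1ccc2c(NCc3ccco3)nc(NC(C)C)nc2c1` and compound 2 `Cc1ccc2nc(NC(C)C)nc(NCc3ccco3)c2c1` contain the same atoms joined differently; the difference between the two cores is not broken down here. In a physicochemical assay for solubility, at pH 7.4 (on this read-out higher numbers stand for higher solubility and lower numbers for lower solubility), compound 1 gives only a limit of <= 20000 nM. In this assay compound 2 also gives only a limit, <= 20000 nM. Compound 3 `COc1ccc2c(NCc3ccco3)nc(NC(C)C)nc2c1` comes from compound 1 through (methoxy in place of methyl on an aromatic carbon). In this assay compound 3 again reaches only a limit, <= 20000 nM. The step that the two limits leave unreadable from compound 1 to compound 3 therefore stays unreadable, since (the limit of <= 20000 nM in this assay, at which 3 of the 3 values shown sit). Compound 4 `COc1ccc2nc(NC(C)C)nc(NCc3ccco3)c2c1` arises from compound 2 by the same change, (methoxy in place of methyl on an aromatic carbon). Because (the limit of <= 20000 nM in this assay, at which 3 of the 3 values shown sit), compound 4 is expected to give 8000 nM, most likely reported once more as a limit, within an expected range from 1000 nM to 20000 nM. This means an expected step that the limit leaves unreadable from compound 2 to compound 4, placed beside the unreadable earlier one.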

Compound 4, solubility: >= 30000 nM
Compound 4 gave a limit, no number; the forecaster's own chance of this, stated with the estimate: 85%; at least 3.7-fold (0.57 log units) between middle value and limit.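

In this assay, methoxy in place of methyl on an aromatic carbon gives an at least 1.5-fold higher number from compound 2 to compound 4 (0.17 log units; that floor lies within the scatter), and this is a single pair in which both values are limits. The smallest step that these limits allow does not establish a real difference, and it does not show that the change would act the same way on another core. The same change on the core of compound 1 cannot be read, because both of its values sit at one limit: the limit of <= 20000 nM in this assay, at which 3 of the 4 values shown sit.

The compounds shown leave open how an amine or a carboxylic acid in place of the methoxy would read in this assay. They also leave open whether either core would give an actual number rather than a limit.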